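Hexadecyl glycoside amides: acetyl chain extended to pentenoyl

The source may report more compounds than this note shows. Statements on the series, on what has been measured and on what is new or still open speak of the compounds shown alone.

Among the measured compounds shown here, compound 1 `CC(=O)N[C@H]1[C@@H](OCCCCc2ccccc2)O[C@H](CO)[C@@H](O)[C@@H]1O` and compound 2 `CCCCCCCCCCCCCCCCO[C@H]1O[C@H](CO)[C@@H](O)[C@H](O)[C@H]1NC(C)=O` are the two measured members. In a functional assay on U-373MG ATCC cells (Homo sapiens), read by thymidine incorporation (a lower number here means a stronger inhibitor, a higher number a weaker inhibitor), compound 1 gives > 50 uM, a limit of the assay. In this assay compound 2 gives > 50 uM, again only a limit. For the measured compounds named here, both values sit at the limit of > 50 uM in this assay, at which 2 of the 2 values shown sit, so no step between measured compounds is available. Compound 3 `C=CCCC(=O)N[C@H]1[C@@H](OCCCCCCCCCCCCCCCC)O[C@H](CO)[C@@H](O)[C@@H]1O` differs from compound 2 by allyl in place of hydrogen on a saturated chain carbon bound to a carbonyl carbon. Given that compound 2 is at a limit, no step beyond the scatter is expected in this assay, and a further limit is the likeliest outcome. The estimated step that the limit leaves unreadable from compound 2 to compound 3 is expected to be negligible. Compound 3 is expected at 70 uM, within 20 uM to 250 uM.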

Compound 3, concentration for 50% inhibition: > 50 uM
Compound 3 gave a limit, no number; the forecaster's own chance of this, stated with the estimate: 80%; the middle value lies beyond the limit too.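

Compound 2 and compound 3 both stand at a limit, so no step can be read between them: the limit of > 50 uM in this assay, at which 3 of the 3 values shown sit. The compounds shown leave open whether any member of this series reaches a readable value in this assay.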